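The compounds below may be only part of what the source reports. "The series", "measured", "known", "first", "only" and "open" are said of these compounds alone.

Measured compounds:
Compound 1, `Nc1ccccc1NC(=O)c1ccc(CSC(=S)N2CCc3ccccc32)cc1`: 38%
Compound 2, `CCN(Cc1ccncc1)C(=S)SCc1ccc(C(=O)Nc2ccccc2N)cc1`: 63.5%
Compound 3, `Nc1ccccc1NC(=O)c1ccc(CSC(=S)N2CCN(Cc3ccncc3)CC2)cc1`: 59.5%

In a functional assay on HeLa cells (Homo sapiens) for antiproliferative activity, read by CCK-8 assay, with a stated time of 72 h, tested at 2 uM (on this read-out lower numbers stand for a weaker effect and higher numbers for a stronger effect at the one concentration tested), compound 3 gives 59.5%, the second highest of the three numbers. Its nearest neighbour is compound 2, which gives 63.5%, a gap within the scatter, so the two cannot be ordered. The furthest is compound 1, which gives 38%, a gap beyond the scatter.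

Compound 4, `CN1CCN(C(=S)SCc2ccc(C(=O)Nc3ccccc3N)cc2)CC1`, has not yet been measured. It differs from compound 3 in one place: hydrogen in place of pyridin-4-yl on a saturated chain carbon bound to an amine nitrogen in a ring.

Going by the values given here, only one measured step touches the group on the thiocarbonyl carbon: a number 25.5 percentage points higher from compound 1 to compound 2 (beyond the scatter). That step swaps one amine for another rather than trimming a substituent, so it bears on the present change only loosely. Among the compounds with values here, no measured step removes a pyridin-4-yl group; compound 2 and compound 3 both carry one, and both sit well above compound 1. Within the data shown here, with no direct precedent, a small downward step or none beyond the scatter is expected. Compound 4 is therefore estimated to give 50%, with a range from 30% to 68%. For compound 4 the expected step is a number 9.5 percentage points lower from compound 3 to compound 4 (within the scatter).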

Compound 4, a percentage reported as inhibition, at one concentration (the size of the read-out at that concentration, not a potency): 52.6%
For compound 4 the middle estimate is 2.6 percentage points below the measured one; the range from low to high includes it.
By their numbers in this assay, from the lowest: compound 1; then compounds 4, 3 and 2 (each within the scatter of the next, the first and the last beyond it).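

In this assay, hydrogen in place of pyridin-4-yl on a saturated chain carbon bound to an amine nitrogen in a ring gives a number 6.9 percentage points lower from compound 3 to compound 4 (within the scatter) and so shows that this aromatic ring can be cut back to methyl without a difference that can be told from scatter. The 4-methylpiperazin-1-yl group gives a number 10.9 percentage points lower from compound 2 to compound 4 (beyond the scatter) in place of ethyl((pyridin-4-yl)methyl)amino and a number 14.6 percentage points higher from compound 1 to compound 4 (beyond the scatter) in place of 2,3-dihydro-1H-indol-1-yl, so the margin over compound 1 does not depend on a pyridin-4-yl group. Nothing in hand explains any of these steps.

Open, from the compounds shown here alone, is how a phenyl ring or a longer chain on that ring nitrogen would read here. So is a morpholine in place of the piperazine.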